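Amide-side aryl variation: compounds 1 to 4

This account rests on a few compounds, and the source may have more. Where it says the series, first, only, none or still open, it means among the compounds named here.

Measured compounds:
- compound 1 `O=C(Nc1ccc(Cl)c(-c2nnc3c(Cl)cccn23)c1)c1ccccn1`; in a functional assay on MCF7 cells (Homo sapiens) for antiproliferative activity, read by MTT assay, with a stated time of 72 h (a higher number here means a weaker inhibitor, a lower number a stronger inhibitor), compound 1 gives 96400 nM
- compound 2 `O=C(Nc1ccc(Cl)c(-c2nnc3c(Cl)cccn23)c1)c1ccc(Cl)cc1`; in this assay compound 2 gives 58400 nM
- compound 3 `O=C(Nc1ccc(Cl)c(-c2nnc3c(Cl)cccn23)c1)c1cccnc1Cl`; in this assay compound 3 gives only a limit, > 100000 nM

Compound 2 carries the lowest of the two numbers in this assay; its nearest neighbour is compound 1, and that step, a 1.7-fold lower number from compound 1 to compound 2 (0.22 log units; within the scatter), stays within the scatter. Compound 3 sits at the limit (the limit of > 100000 nM in this assay, at which 1 of the 3 values shown sits), so the steps of an at least 1.0-fold higher number from compound 1 to compound 3 (0.01 log units; that floor lies within the scatter) and an at least 1.7-fold higher number from compound 2 to compound 3 (0.23 log units; that floor lies within the scatter) are floors only, both within the scatter.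

Compound 4 `O=C(Nc1ccc(Cl)c(-c2nnc3c(Cl)cccn23)c1)c1ccccc1` differs from compound 2 by hydrogen in place of chloro on an aromatic carbon. The step from compound 1 to compound 2 is the only measured one that touches the same aryl, and it exchanged the whole group rather than a single chloro; it changed nothing beyond the scatter. On this basis no step beyond the scatter is expected in this assay, in either direction. Compound 4 is therefore estimated at 70000 nM, between 35000 nM and 140000 nM, which means an expected step of a 1.2-fold higher number from compound 2 to compound 4 (0.08 log units; within the scatter).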

Compound 4, half-maximal inhibitory concentration: > 100000 nM
Compound 4 was reported as a limit; the forecaster's own chance of this, stated with the estimate: 25%; middle value at least 1.4-fold (0.15 log units) away from the limit.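

Taking the chloro off the 4-chlorophenyl group is the only change here confined to a single atom, and in this assay compound 4 gives only a limit, > 100000 nM. Hydrogen in place of chloro gives an at least 1.7-fold higher number from compound 2 to compound 4 (0.23 log units; that floor lies within the scatter), and phenyl in place of pyridin-2-yl gives an at least 1.0-fold higher number from compound 1 to compound 4 (0.01 log units; that floor lies within the scatter), so neither change is shown to move the reading, while the step from compound 3 to compound 4 cannot be read. With this result, the upward side of the amide-side aryl can be followed only as far as this: the limit of > 100000 nM in this assay, at which 2 of the 4 values shown sit.

On these data alone, the true size of the step from chloro to hydrogen stays open behind the limit of compound 4. Also open, as far as these compounds go, is how a methoxy group, an amine or a carboxylic acid in place of this chloro would read.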